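From (oxan-4-yl)methyl to 4-methoxybenzyl on the shared core

A few compounds are considered here, and "the series" means these few. Any claim that something is new, unique, unknown or untested is made for them only; others in the source may bear on it.

Measured in a physicochemical assay for solubility, using the shake flask method, in simulated intestinal fluid, measured as kinetic solubility, with a stated time of 2 h, at 25 degrees C, at pH 6.5; on this read-out higher numbers stand for higher solubility and lower numbers for lower solubility:
- compound 1 `Cc1noc(-c2nc(C)c3c(c2N)C(=O)N(Cc2ccccc2)C3=O)n1`: < 5000 nM, a limit of the assay
- compound 2 `Cc1noc(-c2nc(C)c3c(c2N)C(=O)N(Cc2ccc(F)cc2)C3=O)n1`: < 5000 nM, a limit of the assay
- compound 3 `Cc1noc(-c2nc(C)c3c(c2N)C(=O)N(CC2CCOCC2)C3=O)n1`: 5700 nM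

Going by the values given here, compound 3 gives 5700 nM, the only true number in the set. Compound 1 and compound 2 stand at the limit of < 5000 nM in this assay, at which 2 of the 3 values shown sit.

The next structure is compound 4 `COc1ccc(CN2C(=O)c3c(C)nc(-c4nc(C)no4)c(N)c3C2=O)cc1`, and the change is 4-methoxyphenyl in place of oxan-4-yl on a saturated chain carbon bound to an amide-type nitrogen in a ring.

Among the compounds with values here, two measured steps bear on this, both starting from an aromatic ring and ending at oxan-4-yl: an at least 1.1-fold higher number from compound 1 to compound 3 (0.05 log units; that floor lies within the scatter), and an at least 1.1-fold higher number from compound 2 to compound 3 (0.05 log units; that floor lies within the scatter). Both give only a floor, and neither floor clears the scatter. The fluoro swap adds nothing readable, being a step that the two limits leave unreadable from compound 1 to compound 2.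

Compound 4 therefore has no measured step beyond the scatter to lean on, and this assay may well report only a limit for it. The expected change is a 1.6-fold lower number from compound 3 to compound 4 (0.21 log units; within the scatter), which would stay within the scatter. For compound 4 the estimated value is 3500 nM, with an expected range from 1800 nM to 6500 nM.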

Compound 4, solubility: < 5000 nM
Compound 4 gave a limit, no number; the forecaster's own chance of this, stated with the estimate: 75%; the middle value is on the limit's open side.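

In this assay compound 4 gives < 5000 nM, a limit of the assay and not a number. Going by these compounds alone, the only readable step is an at least 1.1-fold lower number from compound 3 to compound 4 (0.05 log units; that floor lies within the scatter), so this change does not separate the two groups on the saturated chain carbon, and the steps from compound 1 and from compound 2 to compound 4 cannot be read. What is new is that a third aromatic ring at this place, now carrying methoxy, sits with compound 1 and compound 2 at one shared value: the limit of < 5000 nM in this assay, at which 3 of the 4 values shown sit.

As far as these compounds go, how far any of these three compounds lies from compound 3 stays open, since none of them has a true number. Also open, from the compounds shown here alone, is whether an amine or a carboxylic acid in place of oxan-4-yl would give a step beyond the scatter.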